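Working notes: benzyl to 4-(tert-butyl)phenoxy on the core

The compounds below may be only part of what the source reports. "The series", "measured", "known", "first", "only" and "open" are said of these compounds alone.

Measured so far:
compound 1 `COc1cccc(CNCCCNc2ccnc3cc(Cc4ccccc4)ccc23)c1O`: 5720 nM
compound 2 `COc1ccc(F)cc1CNCCCNc1ccnc2cc(Cc3ccccc3)ccc12`: 7990 nM
compound 3 `c1coc(CNCCCNc2ccnc3cc(-c4cccc5ccccc45)ccc23)c1`: 5600 nM

In an ADME assay on HepG2 cells (Homo sapiens) for cytotoxicity, read by luminescence, CellTiter-Glo and ATP content, with a stated time of 72 h (a higher number here means that more compound is needed for the effect, a lower number that less compound is needed), compound 1 gives 5720 nM, the second highest of the three numbers; compound 3 and compound 2 both sit within the scatter of it, so the three cannot be told apart. Compound 4 `COc1cccc(CNCCCNc2ccnc3cc(Oc4ccc(C(C)(C)C)cc4)ccc23)c1O` differs from compound 1 as follows: 4-(tert-butyl)phenoxy in place of benzyl on an aromatic carbon. Among the compounds with values here, the only single-place step available is a 1.4-fold higher number from compound 1 to compound 2 (0.15 log units; within the scatter), which alters the group on the saturated chain carbon bound to an amine nitrogen rather than the aromatic carbon changed here, so it bears on the present change only indirectly. Within the data shown here, compound 3 differs from compound 1 in two places, and its value shows no single step. Among the measured compounds shown here, no measured step supports a move beyond the scatter, so the expected step is a 1.3-fold lower number from compound 1 to compound 4 (0.10 log units; within the scatter). Compound 4 is estimated at 4500 nM, with a range from 1500 nM to 13000 nM.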

Compound 4, half-maximal effective concentration: 1500 nM
Estimate against measurement, compound 4: 3.0-fold (0.48 log units) above; the range from low to high includes it.
By their numbers in this assay, from the lowest: compound 4; then compounds 3, 1 and 2 (each within the scatter of the next).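

In this assay, within the data shown here, 4-(tert-butyl)phenoxy in place of benzyl on this aromatic carbon of the shared core gives a 3.8-fold lower number from compound 1 to compound 4 (0.58 log units; beyond the scatter), the first single-place step to lie beyond the scatter. Among these compounds, the only earlier single-place step, a 1.4-fold higher number from compound 1 to compound 2 (0.15 log units; within the scatter), changed the group on the saturated chain carbon and stayed within the scatter. No evidence on hand accounts for the new step.

The compounds shown do not separate the ring oxygen from the tert-butyl group, which plain phenoxy and 4-(tert-butyl)benzyl would do. As far as these compounds go, whether the step carries over to the 5-fluoro-2-methoxyphenyl side chain of compound 2 also stays open.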